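The source may hold more compounds than are shown below. What is called first, only, known or untested is meant among the compounds shown, and "the series" means these compounds.

Three compounds have been measured in a functional assay on the whole organism (artery, strain albino) with Rattus norvegicus as the target, with a stated time of 30 min, at a dose of 10 mg/kg by the oral route; a higher number here means more inhibition at the dose given (going by the name of the read-out), a lower number less inhibition:

Compound 1, `CC1=C(C(=O)Nc2ccc(Br)cc2)C(c2ccc(Cl)cc2Cl)N=C(SCc2ccccc2Cl)N1`, gives 5.7% in this assay.
Compound 2, `CC1=C(C(=O)Nc2ccc(Br)cc2)C(c2ccc(Cl)cc2Cl)N=C(SCc2cccc(Cl)c2)N1`, gives 3.1%.
Compound 3, `CC1=C(C(=O)Nc2ccc([N+](=O)[O-])cc2)C(c2cccc([N+](=O)[O-])c2)N=C(SCc2ccccc2Cl)N1`, gives 3.6%.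

Compound 1 and compound 2 share a core and differ in one place: 3-chlorophenyl in place of 2-chlorophenyl on a saturated chain carbon bound to a sulfur. The measured step is a number 2.6 percentage points lower from compound 1 to compound 2 (within the scatter), so the two values cannot be told apart. Compound 3 carries another core; how it differs from the core of compound 1 is not broken down here. Its value and those of compound 1 and compound 2 all lie within the scatter of one another.

Compound 4, `CC1=C(C(=O)Nc2ccc([N+](=O)[O-])cc2)C(c2cccc([N+](=O)[O-])c2)N=C(SCc2cccc(Cl)c2)N1`, has not yet been measured. It stands to compound 3 as compound 2 stands to compound 1: 3-chlorophenyl in place of 2-chlorophenyl on a saturated chain carbon bound to a sulfur. The place is the same in both pairs, so this is the same change. The step is expected to be a number 1.1 percentage points lower from compound 3 to compound 4 (within the scatter), small, because the same change gave a number 2.6 percentage points lower from compound 1 to compound 2 (within the scatter). Compound 4 is therefore estimated to give 2.5%, with a likely range from -5% to 10%.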

Compound 4, a percentage reported as inhibition, in the whole organism at one dose (the size of the read-out at that dose, not a potency): 4.1%
Compound 4: middle estimate off by 1.6 percentage points, on the low side; the range from low to high includes it.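

Replacing 2-chlorophenyl with 3-chlorophenyl on a saturated chain carbon bound to a sulfur gives, in this assay, a number 0.5 percentage points higher from compound 3 to compound 4 (within the scatter). Set beside the earlier step on the core of compound 1, the two results cannot be told apart: the same change on two cores in this assay, a number 2.6 percentage points lower (within the scatter) from compound 1 to compound 2 and a number 0.5 percentage points higher (within the scatter) from compound 3 to compound 4, 3.1 percentage points apart, within the scatter of two such steps. This shows that the change stays within the scatter on both cores, but it does not show that the change has no effect in general, that it would behave alike on a third core, or how it would read at another dose.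

The compounds shown carry only 2-chlorobenzyl and 3-chlorobenzyl on the sulfur, so what 4-chlorobenzyl, unsubstituted benzyl or a longer alkyl chain would give there remains open. Also open, going by these compounds, is whether a carboxylic acid or an amine in place of the bromo or nitro groups would raise the inhibition enough for a step of this kind to be read beyond the scatter.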